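A few compounds are considered here, and "the series" means these few. Any claim that something is new, unique, unknown or untested is made for them only; others in the source may bear on it.

Two compounds of the series have numbers in a functional assay on SSMC-7721 cells (Homo sapiens) for antiproliferative activity, read by CCK-8 assay, with a stated time of 48 h; a higher number here means a weaker inhibitor, a lower number a stronger inhibitor. Compound 1 `O=c1c2ccccc2[se]n1-c1nnc(-c2ccccc2Cl)s1` gives 40200 nM. For the measured compounds named here, compound 2 `Cc1ccccc1-c1nnc(-n2[se]c3ccccc3c2=O)s1` gives 19400 nM, the lowest of the two numbers, and the single step in hand, a 2.1-fold lower number from compound 1 to compound 2 (0.32 log units; beyond the scatter), is modest but beyond the scatter. Compound 3 `Cc1ccc(-c2nnc(-n3[se]c4ccccc4c3=O)s2)cc1` is the next member and is not yet measured. It differs from compound 2 by 4-methylphenyl in place of 2-methylphenyl on an aromatic carbon; the two have the same atoms, joined differently. Going by the values given here, no measured step bears directly on this change: the one step known, a 2.1-fold lower number from compound 1 to compound 2 (0.32 log units; beyond the scatter), exchanges chloro for methyl on an aromatic carbon and says nothing about exchanging 2-methylphenyl for 4-methylphenyl. With nothing in the data to set a direction, the expected step from compound 2 to compound 3 in this assay is none beyond the scatter, and compound 3 is expected to show no change at the digits printed from compound 2 to compound 3 (within the scatter). The estimate for compound 3 in this assay is therefore 19400 nM, with an expected range from 8000 nM to 47000 nM.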

Compound 3, half-maximal inhibitory concentration: 16600 nM
Beside the measured number, compound 3's estimate is 1.2-fold (0.07 log units) above it; low and high end bracket the measured number.
By their numbers in this assay, from the lowest: compounds 3 and 2 (each within the scatter of the next); then compound 1.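

Within this assay, exchanging 2-methylphenyl for 4-methylphenyl on the aromatic carbon next to the ring nitrogen and next to the ring sulfur gives a 1.2-fold lower number from compound 2 to compound 3 (0.07 log units; within the scatter) and so leaves the number unresolved from that of compound 2; for this pair, where the methyl sits on the phenyl ring does not register in this assay. Exchanging 2-chlorophenyl for 4-methylphenyl gives a 2.4-fold lower number from compound 1 to compound 3 (0.38 log units; beyond the scatter) and thus stands with the earlier chloro-to-methyl step, so that both compounds bearing a methylphenyl group have lower numbers than the chlorophenyl compound 1, though that step changes the substituent and its place on the phenyl ring together. Nothing measured on these compounds accounts for these differences.

From the compounds shown here alone, the effect of the chloro group's place stays open, as a 4-chlorophenyl analogue would separate it from the exchange of chloro for methyl. Also open, going by these compounds, is whether the methyl contributes at all and how far the number can move at this position, which unsubstituted phenyl and phenyl rings carrying an amine, a methoxy group or a carboxylic acid would address.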